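The source may hold more compounds than are shown below. What is called first, only, known or untested is meant among the compounds shown, and "the series" means these compounds.

Working notes on the series. Compound 1 `NS(=O)(=O)c1ccc(C(=O)NNC(=O)c2ccccc2)cc1` and compound 2 `NS(=O)(=O)c1ccc(C(=O)NNC(=O)c2ccc(F)cc2)cc1` share one core; compound 3 `NS(=O)(=O)c1ccc(-c2nnc(-c3ccc(F)cc3)o2)cc1` and compound 4 `NS(=O)(=O)c1ccc(-c2nnc(-c3ccccc3)o2)cc1` share another, and the difference between the two cores is not broken down here. In an assay on cells for inhibition of Amine oxidase [flavin-containing] B (Homo sapiens), read by fluorescence and spectrophotometry, using microsomes, with a stated time of 20 min (a higher number here means a weaker inhibitor, a lower number a stronger inhibitor), compound 1 gives > 100000 nM, which is a limit of the assay and not a number. In this assay compound 2 gives > 100000 nM, again a limit. In this assay, within the data shown here, compound 3 gives 79 nM, the only number in the set, the other two values sitting at the limit of > 100000 nM in this assay, at which 2 of the 3 values shown sit. The change from compound 2 to compound 1 is hydrogen in place of fluoro on an aromatic carbon; its step is a step that the two limits leave unreadable from compound 2 to compound 1, which the two limits leave unreadable. Compound 4 carries the same change on the other core: hydrogen in place of fluoro on an aromatic carbon, at the same place word for word. The measured pair therefore gives no size for this change, and the expectation rests on compound 3 at 79 nM alone. The step from compound 3 to compound 4 is expected to be a 2.0-fold higher number from compound 3 to compound 4 (0.31 log units; beyond the scatter). Compound 4 is estimated at 160 nM, with a range from 40 nM to 700 nM.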

Compound 4, half-maximal inhibitory concentration: 168 nM
The estimate for compound 4 lay 1.1-fold (0.02 log units) below the measured number, and the stated range covers the measured number.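

On the core of compound 3, hydrogen in place of fluoro on an aromatic carbon, para to a large group, gives in this assay a 2.1-fold higher number from compound 3 to compound 4 (0.33 log units; beyond the scatter), a modest step. The same change on the other core cannot be read, because compound 2 and compound 1 both stand at a limit of the assay and not at a number: the limit of > 100000 nM in this assay, at which 2 of the 4 values shown sit. The series therefore gives a size for 4-fluorophenyl to phenyl on one core only, and it neither shows that this size carries over to the other core nor shows that it does not.

The compounds shown leave open how other groups at this same place on the core of compound 3, such as chloro, methoxy or an amine, would compare with fluoro and hydrogen. They also leave open whether any such change would have a readable size on the core of compound 1, where both values shown are limits.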